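The source may report more compounds than this note shows. Statements on the series, on what has been measured and on what is new or still open speak of the compounds shown alone.

Compound 1, `CNCc1cc(-c2cccnc2F)n(S(=O)(=O)c2ccsc2)c1`, gives 98% in a functional assay on the whole organism (strain Jcl:Sprague-Dawley) for inhibition, with Rattus norvegicus as the target, with stated times of 3 min and 3 h, at a dose of 1 mg/kg by the intravenous route; a lower number here means less inhibition, a higher number more inhibition at the dose given (going by the name of the read-out).
Compound 2, `CNCc1cc(-c2cccnc2F)n(S(=O)(=O)c2cccs2)c1`, gives 96% in this assay.
Compound 3, `CNCc1cn(S(=O)(=O)c2cccs2)c(-c2cccnc2F)c1F`, gives 98% in this assay.

Compound 3 stands level with compound 1 at the digits shown, the two together the highest of the three numbers; its furthest neighbour is compound 2, reached by a number 2 percentage points higher from compound 2 to compound 3 (within the scatter). Compound 4, `CNCc1cn(S(=O)(=O)c2ccoc2)c(-c2cccnc2F)c1F`, differs from compound 3 by furan-3-yl in place of thiophen-2-yl on a sulfonyl sulfur. Going by the values given here, the only measured step at the same place is a number 2 percentage points lower from compound 1 to compound 2 (within the scatter), a swap of thiophene attachment that stayed within the scatter. Among the compounds with values here, no measured compound carries a furan ring, so that part of the change rests on no measured step. Compound 4 is therefore expected to move by a number 3 percentage points lower from compound 3 to compound 4 (within the scatter), nothing beyond the scatter. The estimate for compound 4 in this assay is 95%, with a range from 82% to 99%.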

Compound 4, a percentage reported as inhibition, in the whole organism at one dose (the size of the read-out at that dose, not a potency): 95%
Beside the measured number, compound 4's estimate shows no gap at the digits printed; measured number inside the range.
By their numbers in this assay, from the lowest: compounds 4, 2, 1 and 3 (each within the scatter of the next).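

Swapping thiophen-2-yl for furan-3-yl on a sulfonyl sulfur gives, in this assay, a number 3 percentage points lower from compound 3 to compound 4 (within the scatter). The earlier compounds shown here varied only the thiophene attachment, whereas this step shows that the sulfur of the ring on the sulfonyl group can give way to oxygen with the read-out staying within the scatter of compound 3. Nothing available gives a reason for this result. Going by these compounds, what stays open is whether a phenyl ring or a plain methyl group on the sulfonyl sulfur would hold the read-out at this single dose.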